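Terminal aryl halide swap in a bithiophene amidine series

A few compounds are considered here, and "the series" means these few. Any claim that something is new, unique, unknown or untested is made for them only; others in the source may bear on it.

Measured so far:
- compound 1 `N=C(N)c1ccc(-c2ccc(-c3ccc(Cl)cc3)s2)s1` — 1670 nM
- compound 2 `N=C(N)c1ccc(-c2ccc(-c3ccc4ccccc4c3)s2)s1` — 1910 nM

In a functional assay on OVCAR-4 cells (Homo sapiens) for inhibition, read by sulforhodamine B assay, with a stated time of 48 h (a higher number here means a weaker inhibitor of growth, a lower number a stronger inhibitor of growth), compound 1 gives 1670 nM and compound 2 gives 1910 nM. Compound 1 holds the lowest of the two numbers, but its nearest neighbour, compound 2, sits within the scatter of it, so the two cannot be ordered. Both carry the same shared core, and the chloro-substituted ring of compound 1 and the bicyclic ring of compound 2 appear interchangeable here.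

Compound 3 `N=C(N)c1ccc(-c2ccc(-c3ccc(F)cc3)s2)s1` is not yet measured in this assay. It differs from compound 1 in one place: fluoro in place of chloro on an aromatic carbon. Going by the values given here, no comparable step between measured compounds is available. The expected step of a 1.4-fold higher number from compound 1 to compound 3 (0.16 log units; within the scatter) is a small weakening, if any, most likely within the scatter. Compound 3 is estimated at 2400 nM with a range from 1000 nM to 6000 nM.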

Compound 3, concentration for 50% growth inhibition: 1680 nM
The estimate for compound 3 lay 1.4-fold (0.15 log units) above the measured number; the measured number falls inside the stated range.
By their numbers in this assay, from the lowest: compounds 1, 3 and 2 (each within the scatter of the next).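

In this assay fluoro in place of chloro on an aromatic carbon, para to a large group, gives a 1.0-fold higher number from compound 1 to compound 3 (0.00 log units; within the scatter) and so leaves growth inhibition unchanged within the scatter. Going by these compounds alone, this is the first step that isolates a single substituent, and it shows that this position accepts either of these two halogens without a readable difference, something the earlier compounds offered no step to show. No measured evidence bears on why the swap leaves the number flat.

The compounds shown leave open whether this position responds to anything other than a halogen, such as an amine, a carboxylic acid or a methoxy group on the same carbon. Going by these compounds, how a ring with only hydrogen at this position compares with compound 1 also remains open.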